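Methyl in place of methoxy on the aryl urea

The source may report more compounds than this note shows. Statements on the series, on what has been measured and on what is new or still open speak of the compounds shown alone.

Compound 1 `CC1(C)CC(NC(=O)Nc2ccccc2)c2cc(Cl)ccc2O1` carries an unsubstituted phenyl on the urea; in a functional assay (aorta) with Rattus norvegicus as the target (a lower number here means that less compound is needed, a higher number that more compound is needed for the effect), compound 1 gives 7800 nM. Compound 2 `COc1cccc(NC(=O)NC2CC(C)(C)Oc3ccc(Cl)cc32)c1` adds a methoxy to that phenyl. For compound 2 the value > 10000 nM is a limit of this assay, not a number. Compound 3 `COc1cccc(NC(=O)NC2CC(C)(C)Oc3ccc(Br)cc32)c1` also stands at a limit, > 10000 nM. The step of an at least 1.2-fold higher number from compound 1 to compound 2 (0.10 log units; that floor lies within the scatter) is therefore readable only as a floor, and the step that the two limits leave unreadable from compound 2 to compound 3 cannot be sized at all. Compound 4 `Cc1cccc(NC(=O)NC2CC(C)(C)Oc3ccc(Cl)cc32)c1` differs from compound 2 in one place: methyl in place of methoxy on an aromatic carbon. For the measured compounds named here, no measured step separates methyl from methoxy; the only step touching that position, an at least 1.2-fold higher number from compound 1 to compound 2 (0.10 log units; that floor lies within the scatter), says merely that the methoxy did not lower the number below that of compound 1. With compound 2 and compound 3 both sitting at the limit of > 10000 nM in this assay, at which 2 of the 3 values shown sit, the expectation for compound 4 rests on a floor. Compound 4 is expected at 12000 nM, in the range 4000 nM to 40000 nM, with a real chance that this assay again reports only a limit. The expected step that the limit leaves unreadable from compound 2 to compound 4 is thus within the scatter.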

Compound 4, half-maximal effective concentration: > 10000 nM
Compound 4: only a limit was reported (the forecaster's own chance of this, stated with the estimate: 60%); the middle value lies beyond the limit too.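

With 3-methylphenyl, as with 3-methoxyphenyl, this assay ends in a limit and not a number, so the swap of methoxy for methyl on this aromatic carbon yields no measurable response. Against the unsubstituted phenyl of compound 1, the methyl gives only a floor: an at least 1.2-fold higher number from compound 1 to compound 4 (0.10 log units; that floor lies within the scatter). The step between compound 2 and compound 4 cannot be read, and the new result adds one more compound to the same limit: the limit of > 10000 nM in this assay, at which 3 of the 4 values shown sit.

Still open, as far as these compounds go, is whether any group at this place, such as an amine, a hydroxy or a carboxylic acid, brings the number below that of compound 1. Also open, from the compounds shown here alone, is how far compound 2, compound 3 and compound 4 lie past their limits, and whether methyl and methoxy differ at all in this assay.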